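A phenylpiperazine amide in place of the anilinoamino arm

A few compounds are considered here, and "the series" means these few. Any claim that something is new, unique, unknown or untested is made for them only; others in the source may bear on it.

Measured so far:
Compound 1 `O=C(Nc1sc2c(c1C(=O)NNc1ccccc1)CCCCC2)NS(=O)(=O)c1ccccc1`: 15200 nM
Compound 2 `CCCCNC(=O)c1c(NC(=O)NS(=O)(=O)c2ccccc2)sc2c1CCCCC2`: > 100000 nM

In a functional assay on cells (Cancer cell lines, Homo sapiens) for inhibition, with a stated time of 48 h (on this read-out lower numbers stand for stronger inhibition of growth and higher numbers for weaker inhibition of growth), compound 1 gives the only number shown. Compound 2 reaches only a limit, (the limit of > 100000 nM in this assay, at which 1 of the 2 values shown sits). Putting butyl in place of anilino on the amide-type nitrogen gives an at least 6.5-fold higher number from compound 1 to compound 2 (0.81 log units; beyond the scatter). Compound 3 `O=C(Nc1sc2c(c1C(=O)N1CCN(c3ccccc3)CC1)CCCCC2)NS(=O)(=O)c1ccccc1` is not yet measured; it differs from compound 1 by 4-phenylpiperazin-1-yl in place of anilinoamino on a carbonyl carbon. Going by the values given here, only the step from compound 1 to compound 2 bears on this change, and it lies beyond the scatter, so removing the anilinoamino arm is expected to weaken inhibition again, though the entering group keeps a phenyl. Compound 3 is expected to give 35000 nM, from 8000 nM to 100000 nM. That amounts to an expected step of a 2.3-fold higher number from compound 1 to compound 3 (0.36 log units; beyond the scatter).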

Compound 3, concentration for 50% growth inhibition: 36200 nM
For compound 3 the middle estimate is 1.0-fold (0.01 log units) below the measured one; the range from low to high includes it.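

In this assay, the 4-phenylpiperazin-1-yl group on the carbonyl carbon has no hydrogen-bond donors yet still gives a measured number, at the cost of a 2.4-fold higher number from compound 1 to compound 3 (0.38 log units; beyond the scatter). Set against butylamino, it gives an at least 2.7-fold lower number from compound 2 to compound 3 (0.44 log units; beyond the scatter), so in this pair the group carrying a phenyl ring inhibits growth more strongly. The value of compound 2 is a limit: the limit of > 100000 nM in this assay, at which 1 of the 3 values shown sits.

The compounds shown do not separate the part played by the phenyl ring from that of the hydrogen-bond donors. A plain anilino group or a morpholine on this carbonyl carbon would bear on that question.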